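Swapping the benzyl substituent: from chloro to two fluorines

This account rests on a few compounds, and the source may have more. Where it says the series, first, only, none or still open, it means among the compounds named here.

Three compounds share one core and differ only in the group on a saturated chain carbon bound to an oxygen on an aromatic ring. In an assay on CHO-K1 cells for displacement of a labelled ligand from prostaglandin E2 receptor EP1 subtype (Homo sapiens) (on this read-out higher numbers stand for weaker inhibition and lower numbers for stronger inhibition), compound 1 `Cc1cc(C(=O)O)nn1Cc1cc(Br)ccc1OCc1ccc(F)cc1F` gives 0.525 nM, compound 2 `Cc1cc(C(=O)O)nn1Cc1cc(Br)ccc1OCc1ccc(Cl)cc1` gives 8.71 nM, and compound 3 `Cc1cc(C(=O)O)nn1Cc1cc(Br)ccc1OCc1ccc(C(F)(F)F)cc1` gives 35.5 nM. Compound 2 therefore stands second highest of the three numbers, with compound 3 nearest and compound 1 furthest from it.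

Compound 4 `Cc1cc(C(=O)O)nn1Cc1cc(Br)ccc1OCc1c(F)cccc1F` has not yet been measured. Compared with compound 2, the change is 2,6-difluorophenyl in place of 4-chlorophenyl on a saturated chain carbon bound to an oxygen on an aromatic ring. Among the compounds with values here, the one measured step that bears on it is a 17-fold higher number from compound 1 to compound 2 (1.22 log units; beyond the scatter), where a 2,4-difluorophenyl was exchanged for the 4-chlorophenyl; the other step, a 4.1-fold higher number from compound 2 to compound 3 (0.61 log units; beyond the scatter), concerns a different exchange and says little here. Compound 4 brings back a difluorophenyl, though with the fluorines placed as 2,6-difluorophenyl rather than 2,4-difluorophenyl, so the expected direction is toward a lower number, and the expected size is large but not necessarily the full return to compound 1 because the pattern of the fluorines differs from that in 0.525 nM.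

For compound 4 the expected step is a 5.8-fold lower number from compound 2 to compound 4 (0.76 log units; beyond the scatter). Compound 4 is therefore estimated at 1.5 nM, with a likely range from 0.4 nM to 6 nM.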

Compound 4, half-maximal inhibitory concentration: 14.8 nM
Beside the measured number, compound 4's estimate is 9.9-fold (0.99 log units) below it, and the stated range ends below it.
By their numbers in this assay, from the lowest: compound 1; then compounds 2 and 4 (each within the scatter of the next); then compound 3.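

Within this assay, the step of a 28-fold higher number from compound 1 to compound 4 (1.45 log units; beyond the scatter) comes from relocating fluorines alone, as 2,6-difluorophenyl takes the place of 2,4-difluorophenyl on the same saturated chain carbon. Across these compounds, then, having two fluorines on the ring is not enough to give the lowest number, and where they stand on the ring makes a large difference. The exchange of 4-chlorophenyl for 2,6-difluorophenyl, by contrast, gives a 1.7-fold higher number from compound 2 to compound 4 (0.23 log units; within the scatter) even though the halogen and the number of halogens both differ, so this assay does not separate those two groups, and nothing measured here accounts for either result.

The compounds shown leave open whether the low number of compound 1 at 0.525 nM depends on one particular fluorine, which a comparison of 2-fluorophenyl and 4-fluorophenyl would begin to test. They also leave open whether a 2,4-dichlorophenyl group, with chlorines in the same pattern, or a plain unsubstituted phenyl ring would fall closer to compound 1 or to compound 2 on this read-out.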